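The source may hold more compounds than are shown below. What is called first, only, known or untested is meant among the compounds shown, and "the series" means these compounds.

Measured in a functional assay on A2780 cells (Homo sapiens) for inhibition; on this read-out higher numbers stand for weaker inhibition and lower numbers for stronger inhibition:
compound 1 `C#Cc1cc(C)oc(=O)c1`, 3100 nM
compound 2 `CCCCCCC#Cc1cc(C)oc(=O)c1`, 3400 nM
compound 3 `CCCC#Cc1cc(C)oc(=O)c1`, 4800 nM

Compound 3 sits at the upper end of these three numbers, yet its separation from the others is small: the step of a 1.5-fold higher number from compound 1 to compound 3 (0.19 log units; within the scatter) and the step of a 1.4-fold higher number from compound 2 to compound 3 (0.15 log units; within the scatter) both stay inside the scatter. Compound 4 `CCCCC#Cc1cc(C)oc(=O)c1` carries methyl in place of hydrogen on a saturated chain carbon, three bonds along the chain from a triple-bonded carbon. The step from compound 2 to compound 3 bears most directly on this change, since it removed a propyl from the same chain carbon; the step from compound 1 to compound 3 concerns the same chain as well. Neither moved beyond the scatter in this assay. Compound 4 is therefore expected to show no step beyond the scatter, a 1.2-fold lower number from compound 3 to compound 4 (0.08 log units; within the scatter). The estimate for compound 4 is 4000 nM, within 2000 nM to 8000 nM.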

Compound 4, half-maximal inhibitory concentration: 7000 nM
For compound 4 the middle estimate is 1.8-fold (0.24 log units) below the measured one; the measured number falls inside the stated range.
By their numbers in this assay, from the lowest: compounds 1, 2, 3 and 4 (each within the scatter of the next, the first and the last beyond it).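

In this assay, among these compounds, the added methyl gives a 1.5-fold higher number from compound 3 to compound 4 (0.16 log units; within the scatter) and so does not separate the two butyl-side neighbours, but compound 4 is the first compound to stand clear of others, with a 2.1-fold higher number from compound 2 to compound 4 (0.31 log units; beyond the scatter) and with a 2.3-fold higher number from compound 1 to compound 4 (0.35 log units; beyond the scatter) as modest steps. The numbers do not rise steadily with chain length: compound 2, with the longest chain, goes against any such trend. Nothing available explains these steps. As far as these compounds go, whether a hydroxyl or an amine on this chain would shift the number remains open.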